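This account rests on a few compounds, and the source may have more. Where it says the series, first, only, none or still open, it means among the compounds named here.

Of the compounds shown here, three have been measured in an assay (Equus caballus) for inhibition of Thromboxane-A synthase (Homo sapiens), using microsomes; on this read-out higher numbers stand for weaker inhibition and lower numbers for stronger inhibition. Compound 1 `O=C(O)CCC/C=C(/c1ccccc1)c1cccnc1` gives 280 nM, compound 2 `NC(=O)CCCC/C=C(\c1ccccc1)c1cccnc1` gives 400 nM, and compound 3 `CC(C)(CCC/C=C(\c1ccccc1)c1cccnc1)C(=O)O` gives 21 nM, the lowest of the three numbers. For the measured compounds named here, the only single-point step recorded so far, a 19-fold lower number from compound 2 to compound 3 (1.28 log units; beyond the scatter), concerns the chain end and not the geometry of the double bond. Compound 4 `CC(C)(CCC/C=C(/c1ccccc1)c1cccnc1)C(=O)O` is the next compound: the two compounds have the same atoms and bonds and differ only in configuration as drawn: 1 of 1 stereo elements differ; a double bond is drawn E in compound 3 and Z in compound 4. Going by the values given here, no measured step isolates this change. Among the compounds with values here, compounds 1 and 2 carry opposite double-bond geometries as drawn, but they also differ at the chain end, so their values give no clean reading on geometry alone; they show only that both numbers lie well above that of compound 3. With nothing in the data to anchor the direction, the step from compound 3 to compound 4 is expected to be moderate and toward a higher number, a 4.3-fold higher number from compound 3 to compound 4 (0.63 log units; beyond the scatter), on the assumption that the drawn geometry of compound 3 is part of what sets it apart. Compound 4 is therefore estimated at 90 nM, within a range of 15 nM to 600 nM.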

Compound 4, half-maximal inhibitory concentration: 30 nM
Beside the measured number, compound 4's estimate is 3.0-fold (0.48 log units) above it, and the stated range covers the measured number.
By their numbers in this assay, from the lowest: compounds 3 and 4 (each within the scatter of the next); then compounds 1 and 2 (each within the scatter of the next).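

For the compounds shown here, compound 4 gives the first reading of double-bond geometry alone in this assay, where the earlier compounds mixed it with a change at the chain end. With the 1-carboxy-1-methylethyl chain end in place, E and Z as drawn give no change that can be told from the scatter, at a 1.4-fold higher number from compound 3 to compound 4 (0.15 log units; within the scatter). That comparison is clean: the fact that compounds 3 and 4 differ only in the configuration as drawn

The second step holds the drawn Z geometry and shows that 1-carboxy-1-methylethyl in place of carboxy brings a 9.3-fold lower number from compound 1 to compound 4 (0.97 log units; beyond the scatter), so the low numbers go with this chain end on either geometry, in compound 3 and in compound 4. The compounds shown leave open whether geometry is as indifferent with a plain carboxylic acid chain end. They also leave open how a single methyl group on that chain carbon, a longer chain, or a tetrazole in place of the carboxylic acid would read.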